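From trifluoromethyl to fluoro on the sulfonyl aryl ring

The source may report more compounds than this note shows. Statements on the series, on what has been measured and on what is new or still open speak of the compounds shown alone.

For the measured compounds named here, compound 3 `CCOC(=O)c1oc2ccc(N(Cc3ccccc3)S(=O)(=O)c3ccc(C(F)(F)F)cc3)cc2c1C` holds the only number in this set: in a functional assay on HCT-116 cells (Homo sapiens) for inhibition, read by MTT assay, with a stated time of 72 h (on this read-out higher numbers stand for weaker inhibition and lower numbers for stronger inhibition), compound 3 gives 12700 nM. Compound 1 `CCOC(=O)c1oc2ccc(N(Cc3ccccc3)S(=O)(=O)c3cccc(Br)c3)cc2c1C` sits at a limit of the assay, > 40000 nM. Compound 2 `CCOC(=O)c1oc2ccc(N(Cc3ccccc3)S(=O)(=O)c3ccccc3Br)cc2c1C` likewise reaches only a limit, > 40000 nM. The step that the two limits leave unreadable from compound 1 to compound 2 is thus not readable, whereas an at least 3.1-fold lower number from compound 1 to compound 3 (0.49 log units; beyond the scatter) and an at least 3.1-fold lower number from compound 2 to compound 3 (0.49 log units; beyond the scatter) are known only as lower bounds because the limit of > 40000 nM in this assay, at which 2 of the 3 values shown sit, caps them. Compound 4 `CCOC(=O)c1oc2ccc(N(Cc3ccccc3)S(=O)(=O)c3ccc(F)cc3)cc2c1C` differs from compound 3 by fluoro in place of trifluoromethyl on an aromatic carbon. Going by the values given here, both readable steps arrive at compound 3 from rings carrying a bromo group; no measured pair exchanges groups at the same position, so the direction rests on inference. Compound 4 is expected to come out somewhat weaker, by about a 2.0-fold higher number from compound 3 to compound 4 (0.29 log units; within the scatter). In this assay compound 4 is therefore estimated at 25000 nM, plausibly between 8000 nM and 60000 nM.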

Compound 4, half-maximal inhibitory concentration: 33100 nM
Beside the measured number, compound 4's estimate is 1.3-fold (0.12 log units) below it, within the range that was stated.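

For the compounds shown here, for the first time, two groups are exchanged at one ring position, and the exchange is readable: in this assay fluoro in place of trifluoromethyl gives a 2.6-fold higher number from compound 3 to compound 4 (0.42 log units; beyond the scatter). The group on this aromatic carbon therefore affects the read-out, even with both groups on the same carbon of the ring. Against the bromo compounds only floors exist, an at least 1.2-fold lower number from compound 2 to compound 4 (0.08 log units; that floor lies within the scatter) and an at least 1.2-fold lower number from compound 1 to compound 4 (0.08 log units; that floor lies within the scatter), and their true size stays unknown because of the limit: the limit of > 40000 nM in this assay, at which 2 of the 4 values shown sit.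

Going by these compounds, whether an amine, a methoxy group or a carboxylic acid at this position would lower the number further remains open.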